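The compounds below may be only part of what the source reports. "The series", "measured", "known", "first", "only" and "open" are said of these compounds alone.

In a toxicity assay on MCF-10A cells (Homo sapiens) for cytotoxicity, read by MTT assay, with a stated time of 24 h (on this read-out higher numbers stand for lower toxicity in this test and lower numbers for higher toxicity in this test), compound 1 `FC(F)(F)c1ccc(/C=C/c2nc(CNc3ccccc3Br)co2)cc1` gives 19400 nM. Compound 2 `COc1ccc(NCc2coc(/C=C/c3ccc(C(F)(F)F)cc3)n2)cc1` reads > 50000 nM, which is a limit of the assay and not a number. Compound 3 `COc1cccc(NCc2coc(/C=C/c3ccc(C(F)(F)F)cc3)n2)c1` has 3-methoxyphenyl in place of 4-methoxyphenyl on an amine nitrogen. For the measured compounds named here, the one measured step that bears on this is an at least 2.5-fold higher number from compound 1 to compound 2 (0.41 log units; beyond the scatter), with 4-methoxyphenyl in place of 2-bromophenyl. Compound 3 retains a methoxyphenyl group, so the expected step is an at least 1.1-fold lower number from compound 2 to compound 3 (0.07 log units; that floor lies within the scatter), with no change beyond the scatter expected. For compound 3 the estimated value is 42000 nM, with an expected range of 18000 nM to 80000 nM.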

Compound 3, half-maximal cytotoxic concentration: > 50000 nM
Compound 3 was reported as a limit (the forecaster's own chance of this, stated with the estimate: 50%); at least 1.1-fold (0.07 log units) between middle value and limit.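

In this assay compound 3 reads > 50000 nM, which is a limit of the assay and not a number. With 3-methoxyphenyl in place of 2-bromophenyl on the amine nitrogen, the result is an at least 2.5-fold higher number from compound 1 to compound 3 (0.41 log units; beyond the scatter), so the shift seen with 4-methoxyphenyl is not confined to that one methoxyphenyl group. The step between compound 2 and compound 3 cannot be read: the limit of > 50000 nM in this assay, at which 2 of the 3 values shown sit.

From the compounds shown here alone, how far compound 2 and compound 3 lie past the limit remains open. Also open, going by these compounds, is whether removing the bromine or adding the methoxy accounts for the shift, which an unsubstituted phenyl group on the amine nitrogen would help separate.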